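Trifluoromethyl for trifluoromethoxy on the second core

The source may report more compounds than this note shows. Statements on the series, on what has been measured and on what is new or still open speak of the compounds shown alone.

Compound 1 `O=S1(=O)C=Cc2ccc(Nc3cccc(C(F)(F)F)c3)cc21` gives 1310 nM in a functional assay on MDA-MB-231 cells (Homo sapiens) for antiproliferative activity, read by MTT assay, with a stated time of 72 h; a lower number here means a stronger inhibitor, a higher number a weaker inhibitor. Compound 2 `O=S1(=O)C=Cc2ccc(Nc3cccc(OC(F)(F)F)c3)cc21` gives 2080 nM; compound 3 `O=S1(=O)C=Cc2cccc(Nc3ccc(OC(F)(F)F)cc3)c21` gives 2100 nM. The difference between the core of compound 2 and the core of compound 3 is not broken down here. The change trifluoromethyl in place of trifluoromethoxy on an aromatic carbon made a step of a 1.6-fold lower number from compound 2 to compound 1 (0.20 log units; within the scatter). Compound 4 `O=S1(=O)C=Cc2cccc(Nc3ccc(C(F)(F)F)cc3)c21` carries the same kind of change on the other core, (trifluoromethyl in place of trifluoromethoxy on an aromatic carbon); the place differs in that it is para to a large group rather than meta to a large group. A step of about a 1.5-fold lower number from compound 3 to compound 4 (0.18 log units; within the scatter) is expected, resting on the step of a 1.6-fold lower number from compound 2 to compound 1 (0.20 log units; within the scatter) and on compound 3 at 2100 nM. Compound 4 is estimated at 1400 nM, between 700 nM and 2800 nM.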

Compound 4, half-maximal inhibitory concentration: 1200 nM
For compound 4 the middle estimate is 1.2-fold (0.07 log units) above the measured one; the range from low to high includes it.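

The step of a 1.8-fold lower number from compound 3 to compound 4 (0.24 log units; within the scatter) can be set beside the earlier step on the other core, and the two agree: the same change on two cores in this assay, a 1.6-fold lower number (0.20 log units; within the scatter) from compound 2 to compound 1 and a 1.8-fold lower number (0.24 log units; within the scatter) from compound 3 to compound 4, 1.1-fold (0.04 log units) apart, within the scatter of two such steps Trifluoromethyl in place of trifluoromethoxy therefore carries across these two cores with a step of similar size, although on the core of compound 4 the group stands para to a large group. Both steps lie within the scatter, so the pair shows no measurable gain from the change on either core, and it cannot separate the effect of the core from that of the place.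

As far as these compounds go, whether a group of another kind at this place, such as an amine, a nitrile or a carboxylic acid, would give a step beyond the scatter remains open.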